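Replacing 2-nitrophenyl with 2,4-difluorophenyl on the shared core

A few compounds are considered here, and "the series" means these few. Any claim that something is new, unique, unknown or untested is made for them only; others in the source may bear on it.

- Compound 1 `COC(=O)c1ccc(NCc2cncn2Cc2cccc(Cl)c2)cc1-c1ccccc1`: > 10000 nM (a limit)
- Compound 2 `COC(=O)c1ccc(NCc2cncn2Cc2cccc(C#N)c2)cc1-c1ccccc1`: > 10000 nM (a limit)
- Compound 3 `COC(=O)c1ccc(NCc2cncn2Cc2ccccc2[N+](=O)[O-])cc1-c1ccccc1`: 10000 nM

These values come from a toxicity assay on NIH3T3 cells (Mus musculus) for cytotoxicity, read by resazurin assay; on this read-out higher numbers stand for an effect only at larger amounts of compound and lower numbers for an effect already at smaller amounts. Among the compounds with values here, compound 3 gives 10000 nM, the only true number among the three. Compound 1 gives > 10000 nM, which is a limit and not a number. Compound 2 gives > 10000 nM, also a limit.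

The next change leads to compound 4 `COC(=O)c1ccc(NCc2cncn2Cc2ccc(F)cc2F)cc1-c1ccccc1`. It is described by 2,4-difluorophenyl in place of 2-nitrophenyl on a saturated chain carbon bound to an aromatic nitrogen, with 2,4-difluorophenyl in place of 2-nitrophenyl on a saturated chain carbon bound to an aromatic nitrogen.

The measured steps that bear on this change replace the group at the same place: a number no higher from compound 1 to compound 3 (the limit leaves the size open) and a number no higher from compound 2 to compound 3 (the limit leaves the size open). The third measured step is a step that the two limits leave unreadable from compound 1 to compound 2. None of the three has a readable size because of the limit of > 10000 nM in this assay, at which 2 of the 3 values shown sit.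

The data therefore give no sign of a large change at this place, and compound 3 at 10000 nM is the only anchor. In this assay, the expected change, a 1.2-fold higher number from compound 3 to compound 4 (0.08 log units; within the scatter), is none beyond the usual scatter, in neither direction. For compound 4 the estimated value is 12000 nM, with an expected range from 6000 nM to 30000 nM.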

Compound 4, half-maximal effective concentration: > 1000 nM
Compound 4 was reported as a limit (the forecaster's own chance of this, stated with the estimate: 70%); the middle value is on the limit's open side.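

In this assay compound 4 gives > 1000 nM, which is a limit and not a number. Within the data shown here, no step from compound 1, compound 2 or compound 3 to compound 4 can be read, because of this limit: the limit of > 1000 nM in this assay, at which 1 of the 4 values shown sits. The compounds shown leave open whether 2,4-difluorophenyl gives a higher or lower number than 2-nitrophenyl, 3-chlorophenyl or 3-cyanophenyl at this place.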